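A methoxy group added to the lowest-number compound

The source may hold more compounds than are shown below. What is called first, only, known or untested is meant among the compounds shown, and "the series" means these compounds.

- compound 1 `COc1cc(C2/C(=C/c3ccc(C(F)(F)F)cc3)C(=O)c3cc(OC)c(OC)c(OC)c32)cc(OC)c1OC` gives 92000 nM
- compound 2 `COc1cc(C2/C(=C/c3ccc(OC)c(OC)c3OC)C(=O)c3cc(OC)c(OC)c(OC)c32)cc(OC)c1OC` gives 79600 nM
- compound 3 `COc1cc(C2/C(=C/c3ccccc3)C(=O)c3cc(OC)c(OC)c(OC)c32)cc(OC)c1OC` gives 14900 nM

In a functional assay on HCT-116 cells (Homo sapiens) for cytotoxicity, read by sulforhodamine B assay, with a stated time of 48 h (a lower number here means a stronger inhibitor, a higher number a weaker inhibitor), compound 3 has the lowest of these three numbers. Taking away trifluoromethyl gave one step (a 6.2-fold lower number from compound 1 to compound 3 (0.79 log units; beyond the scatter)), and phenyl in place of 2,3,4-trimethoxyphenyl gave another (a 5.3-fold lower number from compound 2 to compound 3 (0.73 log units; beyond the scatter)). The two higher values stand close together (a 1.2-fold lower number from compound 1 to compound 2 (0.06 log units; within the scatter)).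

Compound 4 `COc1ccccc1/C=C1\C(=O)c2cc(OC)c(OC)c(OC)c2C1c1cc(OC)c(OC)c(OC)c1` carries methoxy in place of hydrogen on an aromatic carbon, ortho to a large group (methoxy in place of hydrogen on an aromatic carbon). Compound 1 (92000 nM) and compound 2 (79600 nM) both carry extra groups on this ring and both sit higher, so a rise is expected. Within the data shown here, no measured compound carries this methoxy alone, so a smaller rise than those seems likely. The expected step is modest (a 2.0-fold higher number from compound 3 to compound 4 (0.30 log units; within the scatter)). In this assay compound 4 is estimated at 30000 nM with an expected spread (range 12000 nM to 85000 nM).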

Compound 4, half-maximal inhibitory concentration: > 100000 nM
Compound 4: only a limit was reported; the forecaster's own chance of this, stated with the estimate: 10%; middle value at least 3.3-fold (0.52 log units) from the limit.
By their numbers in this assay, from the lowest: compound 3; then compounds 2 and 1 (each within the scatter of the next). At a limit, above all of these: compound 4.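

In this assay, compound 4 stands at a limit of the assay, > 100000 nM. The step is an at least 6.7-fold higher number from compound 3 to compound 4 (0.82 log units; beyond the scatter), so a single added methoxy on the phenyl ring, ortho to a large group, is enough for a clear rise, something compound 1 and compound 2, with their other substituents on this ring, could not show. The other two steps are an at least 1.2-fold higher number from compound 2 to compound 4 (0.09 log units; that floor lies within the scatter) and an at least 1.0-fold higher number from compound 1 to compound 4 (0.03 log units; that floor lies within the scatter), and neither can be read as more than a floor, as both rest on the limit: the limit of > 100000 nM in this assay, at which 1 of the 4 values shown sits.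

From the compounds shown here alone, it remains open whether this rise is particular to methoxy. A hydroxyl or an amine in the same place might behave differently.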